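Benzyl ether in place of the succinate ester on a chroman core

This account rests on a few compounds, and the source may have more. Where it says the series, first, only, none or still open, it means among the compounds named here.

Compound 1, `C=CCOc1c(C)c(C)c2c(c1C)CCC(C)(COc1ccc(/C=C3\SC(=O)NC3=O)cc1Br)O2`, gives 98% in a functional assay on MCF7 cells (Homo sapiens), tested at 5 uM; a higher number here means a weaker effect of the compound at the concentration tested, a lower number a stronger effect.
Compound 2, `Cc1c(C)c2c(c(C)c1OC(=O)CCC(=O)O)CCC(C)(COc1ccc(/C=C3\SC(=O)NC3=O)cc1)O2`, gives 98% in this assay.
Compound 3, `CC(C)=CCOc1c(C)c(C)c2c(c1C)CCC(C)(COc1ccc(/C=C3\SC(=O)NC3=O)cc1-c1ccc(F)cc1)O2`, gives 92% in this assay.

Compound 2 stands level with compound 1 at the digits shown, and together they are the highest of the three numbers; compound 3 differs from compound 2 only within the scatter. All three values therefore show little effect at the tested concentration. Compound 4, `Cc1c(C)c2c(c(C)c1OCc1ccccc1)CCC(C)(COc1ccc(/C=C3\SC(=O)NC3=O)cc1)O2`, differs from compound 2 by benzyl in place of (2-carboxyethyl)carbonyl on an oxygen on an aromatic ring. Among the measured compounds shown here, no step between measured compounds is available, and the three numbers give no sign that a change at this oxygen moves the read-out. The expected step of a number 3 percentage points lower from compound 2 to compound 4 (within the scatter) in this assay is none beyond the scatter. Compound 4 is expected to give 95%, with a range from 80% to 105%.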

Compound 4, a percentage reported as activity, at one concentration (the size of the read-out at that concentration, not a potency): 42%
Estimate against measurement, compound 4: 53 percentage points above, outside the stated range (below it).
By their numbers in this assay, from the lowest: compound 4; then compounds 3, 1 and 2 (each within the scatter of the next).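

Among the compounds shown here, the oxygen on the aromatic ring proves to be a place where a change can move the read-out, which the three earlier compounds, with no step between them, could not show. In this assay, benzyl in place of (2-carboxyethyl)carbonyl gives a number 56 percentage points lower from compound 2 to compound 4 (beyond the scatter) and so turns a near-absent effect into a clear one. No available data explain this step.

From the compounds shown here alone, what remains open is whether the step comes from the arrival of benzyl or the loss of (2-carboxyethyl)carbonyl. A methyl or a longer phenylethyl group on this oxygen could help separate the two.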